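The source may hold more compounds than are shown below. What is called first, only, known or untested is meant among the compounds shown, and "the series" means these compounds.

In a functional assay on MCF7 cells (Homo sapiens) for cytotoxicity, read by WST assay, with a stated time of 72 h (a lower number here means a stronger inhibitor, a higher number a weaker inhibitor), compound 3 `CCCC1(c2ccc(O)cc2)C(=O)Nc2c1ccc(F)c2F` gives only a limit, > 1000 nM, and no number. Compound 1 `CCOc1ccc(C2(c3ccc(O)cc3)C(=O)Nc3c2ccc(F)c3F)cc1`, which carries 4-ethoxyphenyl on the same saturated ring carbon, gives 11 nM. Compound 2 `O=C1Nc2c(ccc(F)c2F)C1(c1ccc(O)cc1)c1cccnc1`, with pyridin-3-yl there, gives 63 nM. Compound 4 `CCCCCC1(c2ccc(O)cc2)C(=O)Nc2c1ccc(F)c2F` keeps the core of compound 3 and extends its propyl to pentyl: ethyl in place of hydrogen on a saturated chain carbon, three bonds along the chain from a saturated ring carbon.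

The measured steps that bear on this change are an at least 90-fold higher number from compound 1 to compound 3 (1.95 log units; beyond the scatter) and an at least 15-fold higher number from compound 2 to compound 3 (1.20 log units; beyond the scatter), both large, and a 5.7-fold higher number from compound 1 to compound 2 (0.76 log units; beyond the scatter), which is modest. All of them exchange the group on the ring carbon, and none lengthens a chain, so they show how far the number can move at this place but do not test the added ethyl directly. Pentyl, like propyl, has no ring, so it is expected to recover only a small part of the gap that separates the chain from the ring-bearing groups. A modest move toward a lower number is therefore expected in this assay, and a result that stays at the limit would not be surprising. The estimated step is an at least 2.0-fold lower number from compound 3 to compound 4 (0.30 log units; that floor lies within the scatter). For compound 4 the expected value is 500 nM, with an estimated range from 100 nM to 2000 nM.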

Compound 4, half-maximal inhibitory concentration: 96 nM
Compound 4: the middle estimate sits 5.2-fold (0.72 log units) above what was measured; measured number outside the range, below it.
By their numbers in this assay, from the lowest: compound 1; then compounds 2 and 4 (each within the scatter of the next). At a limit, above all of these: compound 3.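

Among the compounds shown here, the ethyl added to the propyl chain of compound 3 is enough by itself to change the result in this assay (an at least 10-fold lower number from compound 3 to compound 4 (1.01 log units; beyond the scatter)), something the earlier steps could not show, as each of them exchanged the whole group on the saturated ring carbon. A ring in that group is therefore not required for activity of this order: pentyl in compound 4 cannot be told apart from pyridin-3-yl in compound 2 (a 1.5-fold higher number from compound 2 to compound 4 (0.18 log units; within the scatter)), although 4-ethoxyphenyl in compound 1 still holds a real advantage over pentyl (an 8.7-fold higher number from compound 1 to compound 4 (0.94 log units; beyond the scatter)). From the compounds shown here alone, compound 3 gives only a limit, so the step to the longer chain can be read only as a floor, and its full size stays unknown: the limit of > 1000 nM in this assay, at which 1 of the 4 values shown sits.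

The compounds shown leave open whether the number changes smoothly through butyl or keeps falling with a longer chain such as heptyl. They also leave open whether a pentyl chain carrying a hydroxyl or an amine would keep the result seen with plain pentyl.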